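The compounds below may be only part of what the source reports. "The series", "measured", "known", "first", "only" and "open" are said of these compounds alone.

Measured compounds: compound 1 `CON(C)C(=O)c1ccc(-c2ccc(OCC3CCN(C(=O)OC(C)(C)C)CC3)cn2)cc1F`, compound 2 `CCc1cnc(N2CCC(COc3ccc(-c4ccc(C(=O)N(C)OC)cc4)nc3)CC2)nc1`, compound 3 `CON(C)C(=O)c1ccc(-c2ccc(OCC3CCN(C(=O)OC(C)C)CC3)cn2)cc1`.

In a functional assay on cells for agonist activity at Glucose-dependent insulinotropic receptor (Homo sapiens), read by a luciferase reporter, with a stated time of 6 h (on this read-out higher numbers stand for an effect only at larger amounts of compound and lower numbers for an effect already at smaller amounts), compound 1 gives 73 nM, compound 2 gives 319 nM, and compound 3 gives 155 nM. Compound 2 thus has the highest number of the three. For the measured compounds named here, the only single-site step recorded is a 2.1-fold lower number from compound 2 to compound 3 (0.31 log units; beyond the scatter). Compound 4 `CCc1cnc(N2CCC(COc3ccc(-c4ccc(C(=O)N(C)OC)c(F)c4)nc3)CC2)nc1` differs from compound 2 by fluoro in place of hydrogen on an aromatic carbon, a fluoro in place of hydrogen on an aromatic carbon, ortho to a methoxy(methyl)carbamoyl group. Going by the values given here, no measured step isolates this change: compound 1 and compound 3 differ in two places, so their values show only what each compound gives. In this assay compound 4 is therefore expected to show a 1.8-fold lower number from compound 2 to compound 4 (0.25 log units; within the scatter), with an estimate of 180 nM and a range from 70 nM to 450 nM.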

Compound 4, half-maximal effective concentration: 77 nM
Compound 4: middle estimate off by 2.3-fold (0.37 log units), on the high side, within the range that was stated.
By their numbers in this assay, from the lowest: compounds 1, 4 and 3 (each within the scatter of the next, the first and the last beyond it); then compound 2.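

In this assay, for the compounds shown here, fluoro in place of hydrogen, ortho to the methoxy(methyl)carbamoyl group, gives a 4.1-fold lower number from compound 2 to compound 4 (0.62 log units; beyond the scatter), the only step here that isolates this change. With that fluoro present, the step between the two groups on the ring amine nitrogen is a 1.1-fold higher number from compound 1 to compound 4 (0.02 log units; within the scatter), so 5-ethylpyrimidin-2-yl and tert-butoxycarbonyl are not told apart in this setting. Nothing available explains the effect of the fluoro. As far as these compounds go, it remains open whether chloro or methyl on this aromatic carbon would give a similar step. Also open, from the compounds shown here alone, is whether the fluoro step holds with isopropoxycarbonyl on the ring nitrogen.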